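Longer fluorinated tails on a shared sugar-like core

The compounds below may be only part of what the source reports. "The series", "measured", "known", "first", "only" and "open" are said of these compounds alone.

Compound 1 `O=C(CCC(F)(F)C(F)(F)C(F)(F)C(F)(F)F)NCCCCCCCCCN[C@@H]1[C@H](O)[C@@H](O)[C@H](O)[C@H]2COC(=O)N21`, compound 2 `O=C(CCC(F)(F)C(F)(F)C(F)(F)C(F)(F)C(F)(F)C(F)(F)F)NCCCCCCCCCN[C@@H]1[C@H](O)[C@@H](O)[C@H](O)[C@H]2COC(=O)N21` and compound 3 `O=C(CCC(F)(F)C(F)(F)C(F)(F)C(F)(F)C(F)(F)C(F)(F)F)NCCCCCCCCCN[C@@H]1[C@H](O)[C@@H](O)[C@@H](O)[C@H]2COC(=O)N21` were tested in a functional assay on A549 cells (Homo sapiens) for inhibition, read by sulforhodamine B assay, with a stated time of 48 h; a lower number here means a stronger inhibitor of growth, a higher number a weaker inhibitor of growth. For compound 1 the assay gave only a limit, > 100000 nM. Compound 2 gave 12000 nM in this assay. Compound 3 gave 17000 nM. The change from compound 1 to compound 2 is 1,1,2,2,2-pentafluoroethyl in place of fluoro on a saturated chain carbon bound to two fluorine atoms and a saturated chain carbon, and it brought an at least 8.3-fold lower number from compound 1 to compound 2 (0.92 log units; beyond the scatter); because of the limit of > 100000 nM in this assay, at which 1 of the 3 values shown sits, only a bound of that step is known. The difference between compound 2 and compound 3 is a 1.4-fold higher number from compound 2 to compound 3 (0.15 log units; within the scatter), which fits (the fact that compounds 2 and 3 differ only in the configuration as drawn). How the cores of compound 1 and compound 3 differ is not broken down here.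

Compound 4 `O=C(CCC(F)(F)C(F)(F)C(F)(F)C(F)(F)C(F)(F)C(F)(F)C(F)(F)C(F)(F)F)NCCCCCCCCCN[C@@H]1[C@H](O)[C@@H](O)[C@@H](O)[C@H]2COC(=O)N21` has not been measured. It differs from compound 3 by 1,1,2,2,2-pentafluoroethyl in place of fluoro on a saturated chain carbon bound to two fluorine atoms and a saturated chain carbon, the same change that took compound 1 to compound 2. Compound 4 is expected to give 6000 nM in this assay, likely between 2000 nM and 17000 nM. This means an expected 2.8-fold lower number from compound 3 to compound 4 (0.45 log units; beyond the scatter), a smaller step than the earlier one. That expectation rests on compound 3 already giving a number, 17000 nM, rather than a limit.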

Compound 4, concentration for 50% growth inhibition: > 100000 nM
Compound 4 was reported as a limit; the forecaster's own chance of this, stated with the estimate: 5%; middle value at least 16-fold (1.22 log units) from the limit.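

Compound 4 gave only a limit in this assay, > 100000 nM, not an exact number. This gives an at least 5.8-fold higher number from compound 3 to compound 4 (0.76 log units; beyond the scatter), so the change from fluoro to 1,1,2,2,2-pentafluoroethyl did not carry over from one core to the other, and the two steps point in opposite directions: the same change on two cores in this assay, an at least 8.3-fold lower number (0.92 log units; beyond the scatter) from compound 1 to compound 2 and an at least 5.8-fold higher number (0.76 log units; beyond the scatter) from compound 3 to compound 4, at least 49-fold (1.69 log units) apart, beyond the scatter of two such steps This does not show why the direction reversed, and the true size of each step remains unknown because each rests on a limit: the limit of > 100000 nM in this assay, at which 2 of the 4 values shown sit.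

The compounds shown leave open how the tail of compound 4 would behave on the core of compound 2, which could help separate the effect of the tail from that of the core. Also open, going by these compounds, is whether an amine or a carboxylic acid at the end of the tail, in place of the fluorinated end, would give a measurable number.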